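A few compounds are considered here, and "the series" means these few. Any claim that something is new, unique, unknown or untested is made for them only; others in the source may bear on it.

The study turns on a shared core varied in two places. Compound 1 `CCN1CCCC1CNC(=O)c1cc(N(C)S(C)(=O)=O)c(C)cc1OC` is the reference: in a functional assay on the whole organism for inhibition, with Mus musculus as the target (a higher number here means that more compound is needed for the effect, a lower number that less compound is needed), compound 1 gives 26.1 mg/kg. Compound 2 `CCN1CCCC1CNC(=O)c1cc(N(C)S(C)(=O)=O)c(Cl)cc1OC` differs from it by chloro in place of methyl on an aromatic carbon, and in this assay compound 2 gives 7.7 mg/kg, which is a 3.4-fold lower number from compound 1 to compound 2 (0.53 log units; beyond the scatter). Compound 3 `CCN1CCCC1CNC(=O)c1cc(N(C)S(=O)(=O)N(C)C)c(C)cc1OC` differs from compound 1 by dimethylamino in place of methyl on a sulfonyl sulfur. In this assay compound 3 reaches only a limit of the assay, > 50 mg/kg, namely (the limit of > 50 mg/kg in this assay, at which 1 of the 3 values shown sits). That limit means an at least 1.9-fold higher number from compound 1 to compound 3 (0.28 log units; that floor lies within the scatter). Compound 4 `CCN1CCCC1CNC(=O)c1cc(N(C)S(=O)(=O)N(C)C)c(Cl)cc1OC` differs from compound 3 by chloro in place of methyl on an aromatic carbon, the same kind of change as that between compound 1 and compound 2, though here it stands ortho to a (dimethylsulfamoyl)(methyl)amino group rather than to a methyl(methylsulfonyl)amino group. For compound 4 in this assay a step of an at least 1.6-fold lower number from compound 3 to compound 4 (0.22 log units; that floor lies within the scatter) is expected, because the same kind of change gave a 3.4-fold lower number from compound 1 to compound 2 (0.53 log units; beyond the scatter). Compound 4 is therefore estimated at 30 mg/kg, between 12 mg/kg and 100 mg/kg.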

Compound 4, dose for half-maximal effect: 31.8 mg/kg
For compound 4 the middle estimate is 1.1-fold (0.03 log units) below the measured one; low and high end bracket the measured number.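

On the core of compound 3, chloro in place of methyl on an aromatic carbon gives, in this assay, an at least 1.5-fold lower number from compound 3 to compound 4 (0.19 log units; that floor lies within the scatter), and this stands beside the earlier step: the same change on two cores in this assay, a 3.4-fold lower number (0.53 log units; beyond the scatter) from compound 1 to compound 2 and an at least 1.5-fold lower number (0.19 log units; that floor lies within the scatter) from compound 3 to compound 4; the limit leaves it open whether they differ. On the core of compound 2, dimethylamino in place of methyl on a sulfonyl sulfur gives a 4.1-fold higher number from compound 2 to compound 4 (0.62 log units; beyond the scatter), and this too stands beside its earlier step: the same change on two cores in this assay, an at least 1.9-fold higher number (0.28 log units; that floor lies within the scatter) from compound 1 to compound 3 and a 4.1-fold higher number (0.62 log units; beyond the scatter) from compound 2 to compound 4; the limit leaves it open whether they differ. Each change thus points the same way on both cores, but whether its size carries over is not shown, since compound 3 stands only at a limit: the limit of > 50 mg/kg in this assay, at which 1 of the 4 values shown sits.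

The compounds shown leave open whether other groups on the aromatic carbon, such as fluoro or methoxy, would follow the same direction. The same holds for other groups on the sulfonyl sulfur, such as ethyl or a cyclic amine.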